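Ring-opened sulfonamide on a chlorophenoxyacetic acid scaffold

This account rests on a few compounds, and the source may have more. Where it says the series, first, only, none or still open, it means among the compounds named here.

Measured compounds:
- compound 1 `CCS(=O)(=O)c1ccc(C)c(C#Cc2cc(Cl)ccc2OCC(=O)O)c1`: 8.6 nM
- compound 2 `Cc1ccc(S(=O)(=O)N2CCCCC2C)cc1C#Cc1cc(Cl)ccc1OCC(=O)O`: 1.9 nM

Compound 2 carries the lowest of the two numbers obtained so far in an assay on CHO cells for displacement of a labelled ligand from prostaglandin D2 receptor 2 (Homo sapiens), read by scintillation counting; on this read-out higher numbers stand for weaker inhibition and lower numbers for stronger inhibition. Its nearest neighbour is compound 1, which differs only at the sulfonyl sulfur, and the step of a 4.5-fold lower number from compound 1 to compound 2 (0.66 log units; beyond the scatter) shows how much the change at that position moved the read-out.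

Compound 3 `Cc1ccc(S(=O)(=O)N(C)CC(C)C)cc1C#Cc1cc(Cl)ccc1OCC(=O)O` is the next member of the series and has not been measured. It differs from compound 2 in one place: isobutyl(methyl)amino in place of 2-methylpiperidin-1-yl on a sulfonyl sulfur. Within the data shown here, the only measured step that touches this position is the one from compound 1 to compound 2, which exchanged a small ethyl for the ring-containing amine; it was modest in size and went downward. The change to compound 3 keeps a nitrogen on the sulfonyl sulfur and keeps a similar count of heavy atoms, so the expectation is that compound 3 stays close to compound 2 and that the step of a 1.6-fold higher number from compound 2 to compound 3 (0.20 log units; within the scatter) is expected to remain within the usual scatter or be only slightly upward. The estimated value for compound 3 in this assay is 3 nM, with a range from 1 nM to 9 nM.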

Compound 3, inhibition constant: 4.2 nM
For compound 3 the middle estimate is 1.4-fold (0.15 log units) below the measured one; the range from low to high includes it.
By their numbers in this assay, from the lowest: compound 2; then compound 3; then compound 1.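

In this assay, the ring turns out to matter only modestly: a 2.2-fold higher number from compound 2 to compound 3 (0.34 log units; beyond the scatter), so exchanging 2-methylpiperidin-1-yl for isobutyl(methyl)amino on the sulfonyl sulfur gives a small but real loss of inhibition. A ring on the sulfonyl nitrogen is still not needed for a lower number than the ethyl compound gives, since the open-chain amine retains part of the gain: a 2.0-fold lower number from compound 1 to compound 3 (0.31 log units; beyond the scatter). Both amines on the sulfonyl sulfur thus give lower numbers than ethyl, with the ring-containing amine lowest of the three, but nothing available explains these differences.

These compounds cannot show which feature of the amine accounts for the gap. The ring and the branched chain are exchanged together in a single step. Plain piperidin-1-yl, without its methyl group, and the smaller dimethylamino group on the same sulfonyl sulfur remain open comparisons that could show how much of the gain belongs to the ring, to the methyl group or simply to having an amine there.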